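The source may report more compounds than this note shows. Statements on the series, on what has been measured and on what is new or still open speak of the compounds shown alone.

Compound 2 `COc1ccc(-c2cnc(NC(=O)c3cccc(C#N)c3)n2C)cc1` is the starting point here. In a toxicity assay on THP-1 cells (Homo sapiens) for inhibition (on this read-out higher numbers stand for lower toxicity in this test and lower numbers for higher toxicity in this test), compound 2 gives only a limit of the assay, > 100000 nM, so no number fixes where it stands. Its near relative, compound 1 `COc1ccc(-c2cnc(NC(=O)c3cccc([N+](=O)[O-])c3)n2C)cc1`, likewise gives only a limit in this assay, > 100000 nM. Among the compounds with values here, the single measured step, a step that the two limits leave unreadable from compound 1 to compound 2, therefore has no readable size, because both values sit at the limit of > 100000 nM in this assay, at which 2 of the 2 values shown sit.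

Compound 3 `COc1ccc(-c2cnc(NC(=O)C3CCOCC3)n2C)cc1` differs from compound 2 by oxan-4-yl in place of 3-cyanophenyl on a carbonyl carbon. Within the data shown here, no measured step covers an exchange of this kind, and the only step available yields no size at all, so nothing in the data points to a shift beyond the scatter in this assay. Compound 3 is accordingly expected to sit at 100000 nM, within a range from 40000 nM to 300000 nM. The expected step, a number no higher from compound 2 to compound 3 (the limit leaves the size open), is thus estimated as essentially no change.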

Compound 3, half-maximal cytotoxic concentration: > 100000 nM
Compound 3 gave a limit, no number (the forecaster's own chance of this, stated with the estimate: 80%); the middle value lies on the limit itself.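

No size can be read for the step between compound 2 and compound 3 in this assay, because both values are limits and not numbers: the limit of > 100000 nM in this assay, at which 3 of the 3 values shown sit. The compounds shown leave open whether any exchange of the group on the carbonyl carbon changes the result in this assay.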